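The compounds below may be only part of what the source reports. "The series", "measured", "known", "first", "only" and "open" are said of these compounds alone.

Measured so far in an ADME assay on the whole organism for pharmacokinetics, with Rattus norvegicus as the target, at a dose of 5 mg/kg by the oral route; on this read-out higher numbers stand for higher exposure at the dose given and lower numbers for lower exposure:
compound 1, `O=C1CN(CCC2CCOCC2)c2nc(-c3ccc(-c4nc[nH]n4)nc3)cnc2N1`: 73.2 ng.h/mL
compound 2, `COCCN1C(=O)CNc2ncc(-c3ccc(-c4nc[nH]n4)nc3C)nc21`: 5140 ng.h/mL

In this assay compound 2 gives 5140 ng.h/mL, the higher of the two numbers. Compound 1 gives 73.2 ng.h/mL in this assay, and the gap between the two compounds lies beyond the scatter. They differ from each other in more than one place, so no single step is shown between them; only the two values themselves are known.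

Compound 3, `CO[C@H]1CC[C@H](N2C(=O)CNc3ncc(-c4ccc(-c5nc[nH]n5)nc4C)nc32)CC1`, is not yet measured in this assay. It keeps the core of compound 2 and differs from it by 4-methoxycyclohexyl in place of 2-methoxyethyl on an amide-type nitrogen in a ring. Within the data shown here, no step of this kind between measured compounds is available, so the expected size of the step rests on the two measured values alone and on the fact that compound 2 sits at the top of them. A modest downward step is expected, of the size printed as a 1.7-fold lower number from compound 2 to compound 3 (0.23 log units; within the scatter), within or near the scatter rather than beyond it. Compound 3 is expected to give 3000 ng.h/mL in this assay, with a range from 800 ng.h/mL to 9000 ng.h/mL.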

Compound 3, area under the concentration-time curve: 2930 ng.h/mL
Beside the measured number, compound 3's estimate is 1.0-fold (0.01 log units) above it; the measured number falls inside the stated range.
By their numbers in this assay, from the lowest: compound 1; then compounds 3 and 2 (each within the scatter of the next).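

In this assay, the series now has its first step that differs in one place: 4-methoxycyclohexyl in place of 2-methoxyethyl on an amide-type nitrogen in a ring gives a 1.8-fold lower number from compound 2 to compound 3 (0.24 log units; within the scatter). This position therefore accepts a group of 8 heavy atoms with one six-membered non-aromatic ring of carbon only and 2 defined stereocentres in place of an open chain of 4 heavy atoms, with the hydrogen-bond acceptor count unchanged and no difference beyond the scatter in oral exposure in the rat. No measurement here bears on why the two numbers stay this close, so the result stands as an observation for this one pair on the shared core.

The compounds shown leave open whether this tolerance extends to other groups at this nitrogen, such as a longer chain like 3-methoxypropyl, or to an amine or a carboxylic acid in place of the methoxy group on the cyclohexyl ring. They also leave open how the other arrangement of the two stereocentres of 4-methoxycyclohexyl would read out, since only one arrangement stands in this series.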